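The source may report more compounds than this note shows. Statements on the series, on what has been measured and on what is new or still open speak of the compounds shown alone.

Compound 1 `Cc1nc(-c2ccccc2NCC2=NCCN2)no1`: in a functional assay for activation of Alpha-1A adrenergic receptor (Homo sapiens), read by calcium flux (on this read-out higher numbers stand for an effect only at larger amounts of compound and lower numbers for an effect already at smaller amounts), compound 1 gives 724 nM.
Compound 2 `c1ccc(-c2ccccc2NCC2=NCCN2)nc1`: in this assay compound 2 gives 6.76 nM.

For the measured compounds named here, compound 2 stands at the lowest number of the two measured, with compound 1 as its only neighbour; the single measured step, a 110-fold lower number from compound 1 to compound 2 (2.03 log units; beyond the scatter), shows how strongly this one position on the shared core governs the read-out. Compound 3 `CO/N=C(\C)c1ccccc1NCC1=NCCN1` carries a group of 5 heavy atoms (3 carbon, 1 nitrogen, 1 oxygen; no ring) in place of a group of 6 heavy atoms (5 carbon, 1 nitrogen; one six-membered aromatic ring with 1 hetero atom), on an aromatic carbon. The same position that was altered between compound 1 and compound 2 is altered again, now toward a group without any ring. Going by the values given here, that step is the only guide, and it was large; a move away from the pyridin-2-yl group is therefore expected to cost potency, though the new group is unlike either measured one, so the size is uncertain. Compound 3 is thus expected to give 150 nM in this assay, within 20 nM to 1200 nM, a step of a 22-fold higher number from compound 2 to compound 3 (1.35 log units; beyond the scatter).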

Compound 3, half-maximal effective concentration: 20.9 nM
Compound 3: the middle estimate sits 7.2-fold (0.86 log units) above what was measured; low and high end bracket the measured number.
By their numbers in this assay, from the lowest: compound 2; then compound 3; then compound 1.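

A ring at this position is not required for a low number: the group without any ring gives up little against pyridin-2-yl, with a 3.1-fold higher number from compound 2 to compound 3 (0.49 log units; beyond the scatter) in this assay, a modest step even though it lies beyond the scatter. The same group also stands far from 5-methyl-1,2,4-oxadiazol-3-yl, with a 35-fold lower number from compound 1 to compound 3 (1.54 log units; beyond the scatter), so among these three groups the oxadiazole is the one that stands apart, and the large first step cannot be read as the price of leaving pyridin-2-yl. No data are at hand to explain this order of the three groups.

Which part of the ringless group carries its effect stays open, since no simpler group such as methyl is shown on this aromatic carbon. From the compounds shown here alone, how a phenyl ring, an amine or a carboxylic acid would fare in the same place also remains unknown.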